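The source may report more compounds than this note shows. Statements on the series, on what has been measured and on what is new or still open speak of the compounds shown alone.

Of the compounds shown here, three have so far been tested in a functional assay on SW-620 cells (Homo sapiens) for inhibition, read by MTT assay, with a stated time of 4 days (on this read-out higher numbers stand for weaker inhibition and lower numbers for stronger inhibition), and none of them has given a true number. Compound 1 `CCOC(=O)NC(c1ccccc1)c1ccc(Cl)cc1` gives > 100000 nM, which is a limit of the assay and not a measured value. Compound 2 `COc1cc(NC(C)CCCNC(=O)NNC(=O)NCCCC(C)Nc2cc(OC)cc3cccnc23)c2ncccc2c1` gives > 100000 nM, again a limit. Compound 3 `O=C(NC(c1ccccc1)c1ccc(Cl)cc1)NC(c1ccccc1)c1ccc(Cl)cc1` gives > 100000 nM, also a limit. Compound 1 therefore has no rank among the three, and the whole picture so far is the limit of > 100000 nM in this assay, at which 3 of the 3 values shown sit.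

The next compound, compound 4 `NNC(=O)NC(c1ccccc1)c1ccc(Cl)cc1`, keeps the core of compound 1 and changes one group, with aminoamino in place of ethoxy on a carbonyl carbon. Seen one bond further out, ethoxycarbonyl gives way to aminocarbamoyl. Going by the values given here, no pair of tested compounds differs in just one place, so the data show no direct precedent for this change.

The expectation therefore rests on compound 1, with its limit of > 100000 nM, and no clear move in either direction is foreseen in this assay. The expected change is a number no higher from compound 1 to compound 4 (the limit leaves the size open), which would be no larger than the usual scatter. The estimated value for compound 4 is 100000 nM, with an expected range from 40000 nM to 250000 nM, and another limit is the likeliest report.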

Compound 4, half-maximal inhibitory concentration: > 100000 nM
Compound 4 ended at the assay's limit (the forecaster's own chance of this, stated with the estimate: 75%); the middle value lies on the limit itself.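

Compound 1 and compound 4 both stand at a limit of the assay, not at a measured number, and the step between them cannot be read. Still open is whether any change to these structures would give a true number in this assay, where the picture remains a single one: the limit of > 100000 nM in this assay, at which 4 of the 4 values shown sit.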